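A few compounds are considered here, and "the series" means these few. Any claim that something is new, unique, unknown or untested is made for them only; others in the source may bear on it.

Working notes on the series. Of the compounds shown here, two have been measured so far: compound 1 `CC1CCC(=NNc2ccc(Br)cc2Cl)c2ncc(C(=O)O)c(=O)n21` and compound 2 `CC1CCC(N=Nc2ccccc2)=C2N(C)C=C(C(=O)O)C(=O)N21`. In a functional assay on the whole organism with Rattus norvegicus as the target (a higher number here means that more compound is needed for the effect, a lower number that less compound is needed), compound 1 gives > 100 umol/kg, which is a limit of the assay and not a number. In this assay compound 2 gives > 100 umol/kg, likewise a limit of the assay rather than a number. Where compound 2 stands is thus fixed only by the limit of > 100 umol/kg in this assay, at which 2 of the 2 values shown sit, and no step between measured compounds can be read from these two entries.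

Compound 3 `CC1CCC(N=Nc2ccccc2C(=O)O)=C2N(C)C=C(C(=O)O)C(=O)N21` has not yet been measured in this assay. It differs from compound 2 by carboxy in place of hydrogen on an aromatic carbon; cut one bond further out, the same change reads phenyl to 2-carboxyphenyl. Among the compounds with values here, with both measured entries sitting at the limit, there is no measured step on which to size the effect of this change, and the expectation for this assay is a step that the limit leaves unreadable from compound 2 to compound 3 no larger than the usual scatter, in no fixed direction. Compound 3 is accordingly estimated at 150 umol/kg, between 50 umol/kg and 450 umol/kg, with a substantial chance that only a limit is reported once more.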

Compound 3, dose for 50% inhibition: > 100 umol/kg
Compound 3: a limit, no number; the forecaster's own chance of this, stated with the estimate: 70%; the middle value lies beyond the limit too.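

In this assay, within the data shown here, no step between compound 2 and compound 3 can be read, because both entries are limits of the assay and not numbers: the limit of > 100 umol/kg in this assay, at which 3 of the 3 values shown sit.

The compounds shown leave open whether carboxy in place of hydrogen on an aromatic carbon changes the dose needed at all, and what dose any of these compounds would require in this assay for the effect.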